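Swapping phenylsulfanyl for piperidin-1-yl on the side chain

This account rests on a few compounds, and the source may have more. Where it says the series, first, only, none or still open, it means among the compounds named here.

In a functional assay on the whole organism with Rattus norvegicus as the target (a lower number here means that less compound is needed, a higher number that more compound is needed for the effect), compound 3 (`N=c1sc2cc(OC(F)(F)F)ccc2n1CCSc1ccccc1`) gives 4.5 mg/kg. Compound 2 (`CCN(CC)C(=O)Cn1c(=N)sc2cc(OC(F)(F)F)ccc21`) gives 9 mg/kg, and these two values lie within the scatter of each other. Compound 1 (`N=c1sc2cc(OC(F)(F)F)ccc2n1CC(=O)O`) gives > 10 mg/kg, which is a limit of the assay and not a number.

Compound 4 (`N=c1sc2cc(OC(F)(F)F)ccc2n1CCN1CCCCC1`) keeps the shared core and the chain of compound 3 but carries piperidin-1-yl in place of phenylsulfanyl, on a saturated chain carbon, two bonds along the chain from an aromatic nitrogen: piperidin-1-yl in place of phenylsulfanyl on a saturated chain carbon, two bonds along the chain from an aromatic nitrogen.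

Among the compounds with values here, no measured step makes exactly this swap, so the evidence is indirect. Replacing diethylcarbamoyl with (phenylsulfanyl)methyl gave a 2.0-fold lower number from compound 2 to compound 3 (0.30 log units; within the scatter). Within the data shown here, replacing carboxy with (phenylsulfanyl)methyl gave an at least 2.2-fold lower number from compound 1 to compound 3 (0.34 log units; beyond the scatter), the only step beyond the scatter, and compound 4 carries no carboxy group either. Replacing hydroxy with diethylamino gave an at least 1.1-fold lower number from compound 1 to compound 2 (0.04 log units; that floor lies within the scatter). Among the compounds without carboxy, then, a large change in the side chain has moved the number little, so no shift beyond the scatter is expected here. The expected step is a 1.1-fold higher number from compound 3 to compound 4 (0.05 log units; within the scatter), although a single pair gives only weak support.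

The estimated value for compound 4 is 5 mg/kg. The expected range for compound 4 runs from 2 mg/kg to 12 mg/kg.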

Compound 4, dose for half-maximal effect: 2 mg/kg
Compound 4: the middle estimate sits 2.5-fold (0.40 log units) above what was measured; measured number inside the range.
By their numbers in this assay, from the lowest: compound 4; then compounds 3 and 2 (each within the scatter of the next). At a limit, above all of these: compound 1.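

In this assay, within the data shown here, this is the first step among the compounds without carboxy to go beyond the scatter, a 2.3-fold lower number from compound 3 to compound 4 (0.35 log units; beyond the scatter), so the group at the end of this chain does matter, even though phenylsulfanyl and piperidin-1-yl have the same counts of hydrogen-bond donors and acceptors and neither has a net charge. Compound 4 also separates clearly from the amide, a 4.5-fold lower number from compound 2 to compound 4 (0.65 log units; beyond the scatter), a gap that compound 3 did not open from that compound. Compound 1 is held at a limit and not a number, so its step reads only as a floor, an at least 5.0-fold lower number from compound 1 to compound 4 (0.69 log units; beyond the scatter), and the true gap remains unknown: the limit of > 10 mg/kg in this assay, at which 1 of the 4 values shown sits.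

The swap replaces an aromatic carbon ring and its sulfur with a non-aromatic ring containing nitrogen, and these compounds cannot show which of those differences goes with the lower number; a cyclohexyl group on the same chain would help to separate them. Also open, as far as these compounds go, is how other amines, such as morpholin-4-yl or diethylamino, or a longer chain leading to the piperidine, would fare at this position.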